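Swapping phenyl for pyridin-3-yl on a weak inhibitor

This account rests on a few compounds, and the source may have more. Where it says the series, first, only, none or still open, it means among the compounds named here.

Of the compounds shown here, two sharing one core have been tested in a functional assay on HeLa cells (Homo sapiens) for antiproliferative activity, with a stated time of 24 h; on this read-out higher numbers stand for weaker inhibition and lower numbers for stronger inhibition. Compound 1 `NC(=O)c1c(NC(=O)c2ccc(C(F)(F)F)cc2)sc2c1CCN(Cc1c(Cl)cccc1Cl)C2` reaches only a limit there, > 50000 nM. Going by the values given here, compound 2 `NC(=O)c1c(NC(=O)c2ccccc2Cl)sc2c1CCN(C(=S)Nc1ccccc1)C2` gives 46700 nM in this assay, the only plain number so far. Among the compounds with values here, the one other value is a limit: the limit of > 50000 nM in this assay, at which 1 of the 2 values shown sits, belonging to compound 1. Compound 3 `NC(=O)c1c(NC(=O)c2ccccc2Cl)sc2c1CCN(C(=S)Nc1cccnc1)C2` differs from compound 2 in a single place: pyridin-3-yl in place of phenyl on an amide-type nitrogen. Within the data shown here, no measured pair of this kind exists to lean on, so the step is expected to stay within the usual scatter, as a 1.0-fold lower number from compound 2 to compound 3 (0.02 log units; within the scatter). Compound 3 is therefore expected to give about 45000 nM in this assay, between 20000 nM and 100000 nM.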

Compound 3, half-maximal inhibitory concentration: > 50000 nM
Compound 3 was reported as a limit (the forecaster's own chance of this, stated with the estimate: 35%); middle value at least 1.1-fold (0.04 log units) from the limit.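

Pyridin-3-yl in place of phenyl on an amide-type nitrogen gives an at least 1.0-fold higher number from compound 2 to compound 3 (0.02 log units; that floor lies within the scatter) in this assay. The value of compound 3 is a limit, so only this floor can be read, and the swap shows no stronger inhibition at this position. Compound 3 joins compound 1 at that limit: the limit of > 50000 nM in this assay, at which 2 of the 3 values shown sit.

On these data alone, how far the number truly moves stays open. So does what an amine or a longer chain would do on this nitrogen in place of the aromatic ring.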